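The source may report more compounds than this note shows. Statements on the series, on what has been measured and on what is new or still open speak of the compounds shown alone.

Compound 1 `C#CCCCCOc1ccc(-c2nc3ccc(-c4nc5ccc(N6CCN(C)CC6)cc5[nH]4)cc3[nH]2)cc1` and compound 2 `C#CCOCCCCOc1ccc(-c2nc3ccc(-c4nc5ccc(N6CCN(C)CC6)cc5[nH]4)cc3[nH]2)cc1` share one core and differ only in the chain on the aryl oxygen. In an assay on isolated protein for inhibition of DNA topoisomerase 1 (Homo sapiens), with a stated time of 30 min, tested at 50 uM (on this read-out lower numbers stand for less inhibition and higher numbers for more inhibition at the one concentration tested (going by the name of the read-out)), compound 1 gives 5%, and in the same assay compound 2 gives 5%. Within the data shown here, the single measured step, no change at the digits printed from compound 1 to compound 2 (within the scatter), shows that swapping propargyloxy for ethynyl on the saturated chain carbon four bonds from the aryl oxygen leaves this assay unmoved. Compound 2 therefore stands level with compound 1, both at the low end of the read-out.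

Compound 3 `C#CCOc1ccc(-c2nc3ccc(-c4nc5ccc(N6CCN(C)CC6)cc5[nH]4)cc3[nH]2)cc1` is the next member. It differs from compound 2 as follows: ethynyl in place of 3-(propargyloxy)propyl on a saturated chain carbon bound to an oxygen on an aromatic ring. Among the measured compounds shown here, this removes most of the chain rather than exchanging its end, so the one measured step bears on it only loosely; still, that step was flat, and nothing among the measured compounds suggests that the chain length matters here. The expectation is accordingly a step of no change at the digits printed from compound 2 to compound 3 (within the scatter), that is, none beyond the scatter. Compound 3 is thus estimated at 5%, with a range from 0% to 15%.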

Compound 3, a percentage reported as inhibition, at one concentration (the size of the read-out at that concentration, not a potency): 70%
Compound 3: the middle estimate sits 65 percentage points below what was measured, and the stated range ends below it.
By their numbers in this assay, from the lowest: compounds 1 and 2 (each within the scatter of the next); then compound 3.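

Cutting 3-(propargyloxy)propyl back to ethynyl on the saturated chain carbon bound to an oxygen on an aromatic ring gives a number 65 percentage points higher from compound 2 to compound 3 (beyond the scatter) in this assay. Cutting pent-4-yn-1-yl back to ethynyl at the same place gives a number 65 percentage points higher from compound 1 to compound 3 (beyond the scatter) and so shows that the rise appears whichever of the two longer chains leaves, which means the earlier flat step spoke only of exchanging the end of a long chain and not of the position as a whole. Nothing measured here gives a reason for this rise.

The compounds shown leave open where along the chain the read-out turns, since but-3-yn-1-yloxy and other lengths between propargyloxy and the longer chains do not appear among them, and so it cannot be said whether the change is gradual or abrupt. They also leave open whether the terminal triple bond has any part in the result, a question that a plain propoxy or a short chain ending in an amine or a carboxylic acid at this place would address.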